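The compounds below may be only part of what the source reports. "The series", "measured", "known", "first", "only" and "open" are said of these compounds alone.

For the measured compounds named here, compound 1 `CC#CC(CC(=O)O)c1ccc(OCc2ccc3nc(-c4ccc(OC)cc4)cn3c2)cc1` is one of three compounds measured in an assay on isolated protein for agonist activity at Free fatty acid receptor 1 (Homo sapiens); a higher number here means that more compound is needed for the effect, a lower number that less compound is needed. Compound 1 gives 47 nM, the lowest of the three numbers. Compound 2 `CC#CC(CC(=O)O)c1ccc(OCc2ccn3cc(-c4ccc(C(C)C)cc4)nc3c2)cc1` gives 615 nM and compound 3 `CC#CC(CC(=O)O)c1ccc(OCc2ccn3cc(-c4cc(F)ccc4F)nc3c2)cc1` gives 639 nM in this assay; both carry their aryl group on a core arranged differently from that of compound 1, and from compound 2 to compound 3 the change is a 1.0-fold higher number from compound 2 to compound 3 (0.02 log units; within the scatter).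

Compound 4 `CC#CC(CC(=O)O)c1ccc(OCc2ccc3nc(-c4ccc(C(F)(F)F)cc4)cn3c2)cc1` is not yet measured. Compared with compound 1 it has trifluoromethyl in place of methoxy on an aromatic carbon. Going by the values given here, the only measured step, that from compound 2 to compound 3, swaps one aryl group for another on the outer ring and leaves the number unchanged, which hints that a change on this outer ring may matter little, though that step sits on a different core and swaps a whole aryl group rather than a single substituent. The step from compound 1 to compound 4 is therefore expected to stay within the scatter, as a 1.3-fold higher number from compound 1 to compound 4 (0.11 log units; within the scatter). Compound 4 is estimated at 60 nM, with a range from 20 nM to 180 nM in this assay.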

Compound 4, half-maximal effective concentration: 558 nM
The estimate for compound 4 lay 9.3-fold (0.97 log units) below the measured number; measured number above the stated range.
By their numbers in this assay, from the lowest: compound 1; then compounds 4, 2 and 3 (each within the scatter of the next).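

Putting trifluoromethyl in place of methoxy on this aromatic carbon gives a 12-fold higher number from compound 1 to compound 4 (1.07 log units; beyond the scatter) in this assay and so shows that a single substituent at this place can matter a great deal on the core of compound 1. The flat step seen on the other core, a 1.0-fold higher number from compound 2 to compound 3 (0.02 log units; within the scatter), therefore gives no safe guide to changes on this core, where the outer ring is far from indifferent. Nothing available explains why this swap has so large an effect.

For the compounds shown here, with only two groups at this place on the shared core, it remains open whether methoxy helps, trifluoromethyl harms, or both. A methyl group, a chlorine atom or a hydroxyl group here could help to separate these possibilities, and the same swap on the other core would show whether the effect carries across.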